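This account rests on a few compounds, and the source may have more. Where it says the series, first, only, none or still open, it means among the compounds named here.

Compound 2 `CC(C)=CC[C@@H](OC(=O)C1CCOC1)C1=CC(=O)c2c(O)ccc(O)c2C1=O` and compound 1 `CCCCC(O)CC(=O)O[C@H](CC=C(C)C)C1=CC(=O)c2c(O)ccc(O)c2C1=O` share one core and differ only in the group attached to a carbonyl carbon of the ester. In a functional assay on HeLa cells (Homo sapiens) for cytotoxicity, read by MTT assay (a lower number here means a stronger inhibitor, a higher number a weaker inhibitor), compound 1 gives 72200 nM, and compound 2 gives 73500 nM. For the measured compounds named here, these are the only two numbers measured, and compound 2 sits right alongside compound 1: the step of a 1.0-fold higher number from compound 1 to compound 2 (0.01 log units; within the scatter) is within the scatter, so the two cannot be told apart.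

Compound 3 `CC(C)=CC[C@@H](OC(=O)C1CCCO1)C1=CC(=O)c2c(O)ccc(O)c2C1=O` is the next variation at the same spot: oxolan-2-yl in place of oxolan-3-yl on a carbonyl carbon. Going by the values given here, the one measured step that bears on this place, a 1.0-fold higher number from compound 1 to compound 2 (0.01 log units; within the scatter), left the number unmoved even though it exchanged the whole group. A rearrangement within the same ring is therefore expected to produce no step beyond the scatter, a 1.0-fold lower number from compound 2 to compound 3 (0.00 log units; within the scatter). Compound 3 is estimated at 73000 nM in this assay, with a range from 35000 nM to 150000 nM.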

Compound 3, half-maximal inhibitory concentration: 17000 nM
Estimate against measurement, compound 3: 4.3-fold (0.63 log units) above; measured number below the stated range.
By their numbers in this assay, from the lowest: compound 3; then compounds 1 and 2 (each within the scatter of the next).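

In this assay, where the ring is attached now matters: with the same atoms joined differently, oxolan-2-yl in place of oxolan-3-yl on the carbonyl carbon gives a 4.3-fold lower number from compound 2 to compound 3 (0.64 log units; beyond the scatter). Replacing 2-hydroxyhexyl with oxolan-2-yl gives a 4.2-fold lower number from compound 1 to compound 3 (0.63 log units; beyond the scatter), whereas compound 1 and compound 2 could not be told apart, so that earlier pair gave no hint that this position responds to the group attached there. No measurement here explains why the attachment point of the ring counts.

Still open, from the compounds shown here alone, is whether the ring oxygen is needed at all, which a cyclopentyl group on the same carbonyl carbon would test. Also open, going by these compounds, is whether a six-membered oxan-2-yl ring or an amine on the ring would give a lower number than compound 3 does.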